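Working notes: from compound 2 to compound 3

The compounds below may be only part of what the source reports. "The series", "measured", "known", "first", "only" and "open" are said of these compounds alone.

- Compound 1 `N[C@H]1CC[C@H](Nc2c(C(=O)NCc3ccc(Oc4ccccc4)cc3)nc(Br)c3cccnc23)CC1` gives 4000 nM
- Compound 2 `CN(C)CCCNc1c(C(=O)NCc2ccc(F)cc2)nc(Br)c2cccnc12` gives 7000 nM

In a functional assay on MDA-MB-435 cells (Homo sapiens) for cytotoxicity, read by MTT assay, with a stated time of 72 h (a lower number here means a stronger inhibitor, a higher number a weaker inhibitor), compound 2 stands at 7000 nM, within the usual scatter of compound 1 and its 4000 nM. Compound 3 `N[C@H]1CC[C@H](Nc2c(C(=O)NCc3ccc(F)cc3)nc(Br)c3cccnc23)CC1` has 4-aminocyclohexyl in place of 3-(dimethylamino)propyl on a nitrogen on an aromatic ring. Among the measured compounds shown here, no measured step isolates this change. Compound 1 already carries 4-aminocyclohexyl and gives 4000 nM, so no shift beyond the scatter is expected in this assay. The expected step of a 1.4-fold lower number from compound 2 to compound 3 (0.15 log units; within the scatter) is correspondingly small. The estimate for compound 3 is 5000 nM, with an expected range of 1800 nM to 14000 nM.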

Compound 3, half-maximal inhibitory concentration: 6000 nM
Compound 3: middle estimate off by 1.2-fold (0.08 log units), on the low side; the measured number falls inside the stated range.
By their numbers in this assay, from the lowest: compounds 1, 3 and 2 (each within the scatter of the next).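

In this assay, 4-aminocyclohexyl in place of 3-(dimethylamino)propyl gives a 1.2-fold lower number from compound 2 to compound 3 (0.07 log units; within the scatter) and so the two groups cannot be told apart at this nitrogen, ring or open chain. Fluoro in place of phenoxy gives a 1.5-fold higher number from compound 1 to compound 3 (0.18 log units; within the scatter) and so that aromatic carbon shows no readable effect either. Nothing measured on hand offers a reason for either step.

Going by these compounds, whether any group at these two places can move the number beyond the scatter remains open. A longer chain or morpholine on the nitrogen, or a carboxylic acid in place of fluoro, would test this.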